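The compounds below may be only part of what the source reports. "The series", "measured", "known", "first", "only" and "open" are said of these compounds alone.

Of the compounds shown here, three have so far been tested in a functional assay on K562 cells (Homo sapiens) for antiproliferative activity, read by CCK-8 assay, with a stated time of 72 h; a lower number here means a stronger inhibitor of growth, a higher number a weaker inhibitor of growth. Compound 1 (`CCC1C(=O)N(C)c2cnc(-n3ccc4cc(C(=O)NC)ccc43)nc2N1c1ccn(C)n1`) gives 13300 nM, the highest number of the set, which makes it the weakest growth inhibitor of the three. Compound 2 (`CCCNS(=O)(=O)c1ccc(Nc2ncc3c(n2)N(c2ccn(C)n2)C(CC)C(=O)N3C)cc1`) gives 2260 nM and compound 3 (`CCCNS(=O)(=O)c1ccc(Nc2ncc3c(n2)N(C2CCCC2)[C@H](CC)C(=O)N3C)cc1`) gives 548 nM. Both numbers lie below that of compound 1 by more than the usual scatter of repeat measurements.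

Compound 4 (`CCCNC(=O)c1ccc2c(ccn2-c2ncc3c(n2)N(c2ccn(C)n2)C(CC)C(=O)N3C)c1`) keeps the core of compound 1 and alters one place: ethyl in place of hydrogen on a saturated chain carbon bound to an amide-type nitrogen. In words, this is ethyl in place of hydrogen on a saturated chain carbon bound to an amide-type nitrogen, so methylcarbamoyl becomes propylcarbamoyl.

For the measured compounds named here, no measured pair of compounds differs in only one place, so the effect of this change cannot be read directly from the data. The only hint is thin: compound 2, at 2260 nM, also carries a propylamino group, as does compound 3, at 548 nM, but both differ from compound 1 in other ways too. A modest move towards a lower number is therefore expected in this assay, and no change beyond the scatter remains possible. The expected step is a 2.2-fold lower number from compound 1 to compound 4 (0.35 log units; beyond the scatter). Compound 4 is estimated at 6000 nM, with an expected range of 2000 nM to 16000 nM.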

Compound 4, concentration for 50% growth inhibition: 8270 nM
Estimate against measurement, compound 4: 1.4-fold (0.14 log units) below, within the range that was stated.
By their numbers in this assay, from the lowest: compound 3; then compound 2; then compounds 4 and 1 (each within the scatter of the next).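

In this assay, for the compounds shown here, the change from methylcarbamoyl to propylcarbamoyl gives the first direct reading at this position, and the step reads a 1.6-fold lower number from compound 1 to compound 4 (0.21 log units; within the scatter). Ethyl in place of hydrogen on a saturated chain carbon bound to an amide-type nitrogen therefore leaves growth inhibition unchanged within the scatter, so this one pair shows that the position accepts the added ethyl without a measurable loss or gain. No supporting measurement is available to explain this outcome.

On these data alone, what a longer chain, or a chain ending in an amine or a carboxylic acid, would do in this same place remains open. Going by these compounds alone, it also remains open whether swapping methylcarbamoyl for propylcarbamoyl would give a similar reading with different groups elsewhere on the shared core, as this single pair is the only direct comparison available so far.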